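The compounds below may be only part of what the source reports. "The series", "measured", "known", "first", "only" and "open" are said of these compounds alone.

Compound 1 `COc1cc(C(c2ccc(O)c(OC)c2)[C@@H](C)[C@@H](C)CF)ccc1O`: 42000 nM
Compound 2 `COC[C@@H](C)[C@@H](C)C(c1ccc(O)c(OC)c1)c1ccc(O)c(OC)c1`: > 100000 nM (a limit of the assay, not a number)
Compound 3 `COC[C@@H](C)[C@H](C)C(c1ccc(O)c(OC)c1)c1ccc(O)c(OC)c1`: 58000 nM

All three values come from a functional assay on HeLa cells (Homo sapiens) for cytotoxicity, read by WST assay, with a stated time of 48 h; on this read-out lower numbers stand for stronger inhibition and higher numbers for weaker inhibition. Compound 3, at 58000 nM, sits within the scatter of compound 1, so these two cannot be ranked. Compound 2 gives > 100000 nM, which is a limit of the assay.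

Compound 4 `COc1cc(C(c2ccc(O)c(OC)c2)[C@@H](CF)C(C)C)ccc1O` is the next to be measured. On a saturated chain carbon bound to two aromatic carbons, it carries 1-(fluoromethyl)-2-methylpropyl in place of the 2-(methoxymethyl)-1-methylpropyl of compound 3: 1-(fluoromethyl)-2-methylpropyl in place of 2-(methoxymethyl)-1-methylpropyl on a saturated chain carbon bound to two aromatic carbons.

Within the data shown here, three measured steps bear on this. Exchanging fluoromethyl for methoxymethyl gave a 1.4-fold higher number from compound 1 to compound 3 (0.14 log units; within the scatter), which is a small step. The same kind of exchange also gave an at least 2.3-fold higher number from compound 1 to compound 2 (0.37 log units; beyond the scatter), which goes beyond the scatter but rests on (the limit of > 100000 nM in this assay, at which 1 of the 3 values shown sits). The third step, an at least 1.7-fold lower number from compound 2 to compound 3 (0.23 log units; that floor lies within the scatter), reflects (the fact that compounds 2 and 3 differ only in the configuration as drawn), and its floor lies within the scatter. Among the measured compounds shown here, no measured step shows what rearranging the branches of the chain does, so the range stays wide.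

Compound 1, the measured fluoromethyl relative, gives 42000 nM, so a value in that region is expected. The expected change is small, a 1.2-fold lower number from compound 3 to compound 4 (0.08 log units; within the scatter), and no step beyond the scatter is anticipated. For compound 4 the estimated value is 48000 nM, with an expected range of 20000 nM to 100000 nM.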

Compound 4, half-maximal inhibitory concentration: 41000 nM
The estimate for compound 4 lay 1.2-fold (0.07 log units) above the measured number; measured number inside the range.
By their numbers in this assay, from the lowest: compounds 4, 1 and 3 (each within the scatter of the next). At a limit, above all of these: compound 2.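

In this assay, among these compounds, the new compound is the first to test a rearrangement of the branches of the chain on a saturated chain carbon bound to two aromatic carbons, with the fluorine kept, and the two fluorinated compounds cannot be told apart: a 1.0-fold lower number from compound 1 to compound 4 (0.01 log units; within the scatter). Setting the new group against the 2-(methoxymethyl)-1-methylpropyl group gives a 1.4-fold lower number from compound 3 to compound 4 (0.15 log units; within the scatter), so this pair cannot be ranked either, and at this place the reading so far tolerates both a different branching pattern and a different end group. The step of an at least 2.4-fold lower number from compound 2 to compound 4 (0.38 log units; beyond the scatter) does lie beyond the scatter, but the value of compound 2 is a limit of the assay, so the true size of that step remains unknown: the limit of > 100000 nM in this assay, at which 1 of the 4 values shown sits.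

The compounds shown leave open whether the opposite configuration at the single defined stereocentre of the 1-(fluoromethyl)-2-methylpropyl group would read any differently. They also leave open whether an amine, a carboxylic acid or a longer chain in this place would move the number beyond the scatter from compound 4.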